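Swapping a Hexyl Tail for Phenyl on Compound 2

The source may hold more compounds than are shown below. What is called first, only, known or untested is meant among the compounds shown, and "the series" means these compounds.

Compound 1, `CN(C)CCNc1ccnc2cc(OCc3ccc(F)cc3)ccc12`, gives 370 nM in a functional assay on HCT-116 cells (Homo sapiens) for cytotoxicity, read by MTT assay, with a stated time of 48 h; a higher number here means a weaker inhibitor, a lower number a stronger inhibitor.
Compound 2, `CCCCCCCCOc1ccc2c(Cl)ccnc2c1`, gives 2820 nM in this assay.
Compound 3, `CCOc1ccc2c(NCCN(C)C)ccnc2c1`, gives 2570 nM in this assay.

Among these three, compound 2 carries the highest number. It sits close to compound 3, the two being within the usual scatter of each other, and far from compound 1, which lies beyond that scatter at the lower end.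

Compound 4, `Clc1ccnc2cc(OCCc3ccccc3)ccc12`, is compound 2 with phenyl in place of hexyl on a saturated chain carbon, two bonds along the chain from an oxygen on an aromatic ring. Within the data shown here, only one measured step speaks to a change of this kind: a 6.9-fold higher number from compound 1 to compound 3 (0.84 log units; beyond the scatter), where an aromatic ring on the chain gave way to a methyl and the number rose. Read in the opposite direction, bringing an aromatic ring onto the chain lowered the number in this assay. That step, though, sits on a different core substituent and removes the whole aromatic group rather than exchanging it for a hexyl, so it is a loose guide.

On that basis a lower number is expected for compound 4 than for compound 2, by a modest margin, a 2.6-fold lower number from compound 2 to compound 4 (0.41 log units; beyond the scatter). Compound 4 is estimated at 1100 nM, within a range from 400 nM to 3000 nM.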

Compound 4, half-maximal inhibitory concentration: 2180 nM
For compound 4 the middle estimate is 2.0-fold (0.30 log units) below the measured one; the range from low to high includes it.
By their numbers in this assay, from the lowest: compound 1; then compounds 4, 3 and 2 (each within the scatter of the next).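

At this position on the chain, hexyl and phenyl cannot be told apart in this assay (a 1.3-fold lower number from compound 2 to compound 4 (0.11 log units; within the scatter)). On the core of compound 2, then, swapping an open carbon chain for a six-membered aromatic ring of carbon only, with the same count of heavy atoms, gives no difference beyond the scatter, something the earlier step (a 6.9-fold higher number from compound 1 to compound 3 (0.84 log units; beyond the scatter)) could not show, since that step exchanged the aromatic group for a methyl on a different core. No measurement shown here bears on why the two groups read alike.

The compounds shown leave open whether hexyl and phenyl would also read alike on the core of compound 1, where the only chain change on view is the one to methyl. They also leave open how an amine, a carboxylic acid or a longer chain in place of the phenyl of compound 4 would read in this assay on this same core.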